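The compounds below may be only part of what the source reports. "The series", "measured", "known", "first", "only" and "open" are said of these compounds alone.

Three compounds share one core and differ only in the ring attached to the piperazine. Compound 1 `Cn1c(=O)cnn(CCCCN2CCN(c3ccccc3OCCCF)CC2)c1=O` carries a 3-fluoropropoxy group on that ring, and in an assay for displacement of a labelled ligand from Adrenergic receptor alpha-1 (Homo sapiens) (a lower number here means a stronger inhibitor, a higher number a weaker inhibitor), compound 1 gives 280 nM. Compound 2 `CN(C)c1ccccc1N1CCN(CCCCn2ncc(=O)n(C)c2=O)CC1` carries a dimethylamino group instead, and in this assay compound 2 gives 350 nM. Compound 3 `Cn1c(=O)cnn(CCCCN2CCN(c3ccccc3)CC2)c1=O` has no substituent on that ring, and in this assay compound 3 gives 64 nM, the lowest of the three numbers. The steps of a 4.4-fold lower number from compound 1 to compound 3 (0.64 log units; beyond the scatter) and a 5.5-fold lower number from compound 2 to compound 3 (0.74 log units; beyond the scatter) both show that taking a group off this ring lowered the number, while a 1.3-fold higher number from compound 1 to compound 2 (0.10 log units; within the scatter) shows the two substituted rings close together.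

Compound 4 `Cn1c(=O)cnn(CCCCN2CCN(c3cccc(O)c3)CC2)c1=O` returns a group to the ring: hydroxy in place of hydrogen on an aromatic carbon, on an aromatic carbon of a six-membered aromatic ring of carbon only, meta to a large group; seen one bond further out, phenyl becomes 3-hydroxyphenyl. Going by the values given here, no measured step adds a hydroxy group, and none places a group at this position. The nearest evidence is a 4.4-fold lower number from compound 1 to compound 3 (0.64 log units; beyond the scatter) and a 5.5-fold lower number from compound 2 to compound 3 (0.74 log units; beyond the scatter), read in reverse, where a substituent on the bare ring went with a higher number. A modest rise in this assay is therefore expected for compound 4, a 2.0-fold higher number from compound 3 to compound 4 (0.31 log units; beyond the scatter). For compound 4 the estimate in this assay is 130 nM, with a range from 50 nM to 350 nM.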

Compound 4, inhibition constant: > 10000 nM
Compound 4: no number, only a limit; the forecaster's own chance of this, stated with the estimate: 2%; middle value at least 76-fold (1.88 log units) from the limit.
By their numbers in this assay, from the lowest: compound 3; then compounds 1 and 2 (each within the scatter of the next). At a limit, above all of these: compound 4.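

The value for compound 4 in this assay is a limit of the assay and not a number: the limit of > 10000 nM in this assay, at which 1 of the 4 values shown sits. Going by these compounds alone, with only 1 heavy atom entering, a hydroxy group in place of hydrogen, on an aromatic carbon meta to a large group, produces an at least 150-fold higher number from compound 3 to compound 4 (2.19 log units; beyond the scatter), a large step, whereas the earlier compounds showed only modest steps between the bare ring and a substituted one. The comparison with a substituted ring also comes out large, an at least 28-fold higher number from compound 2 to compound 4 (1.45 log units; beyond the scatter), so the earlier picture of a modest cost for a group on this ring does not extend to 3-hydroxyphenyl.

The compounds shown leave open whether this large step belongs to the hydroxy group itself or to its place on the ring, a question that a methoxy group or a fluorine atom in the same place, or a hydroxy group elsewhere on the ring, could help to separate. The limit also leaves the full size of the step unknown, since it gives no actual number for compound 4.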